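A few compounds are considered here, and "the series" means these few. Any claim that something is new, unique, unknown or untested is made for them only; others in the source may bear on it.

Measured in an ADME assay on HepG2 2.2.15 cells (Homo sapiens) for cytotoxicity; a higher number here means that more compound is tolerated, a lower number that less compound is tolerated:
- compound 1 `CCC(=O)OCCc1c(-c2ccccc2Cl)c2cc(Cl)ccc2[nH]c1=O`: 95000 nM
- compound 2 `CCOCC(=O)OCCc1c(-c2ccccc2Cl)c2cc(Cl)ccc2[nH]c1=O`: 130000 nM
- compound 3 `CC(=O)NCC(=O)OCCc1c(-c2ccccc2Cl)c2cc(Cl)ccc2[nH]c1=O`: 110000 nM

Compound 3 does not separate from the other two in this assay: a 1.2-fold higher number from compound 1 to compound 3 (0.06 log units; within the scatter), and a 1.2-fold lower number from compound 2 to compound 3 (0.07 log units; within the scatter).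

Compound 4 `CC(=O)N1CCC(C(=O)OCCc2c(-c3ccccc3Cl)c3cc(Cl)ccc3[nH]c2=O)CC1` carries this change: 1-acetylpiperidin-4-yl in place of acetamidomethyl on a carbonyl carbon.

The remaining measured step, a 1.4-fold higher number from compound 1 to compound 2 (0.14 log units; within the scatter), is equally small, so all three changes at this end of the molecule stayed within the scatter. None of them brings in a ring, so the data test this feature only indirectly.

No step beyond the scatter and no direction is expected, given a 1.2-fold lower number from compound 2 to compound 3 (0.07 log units; within the scatter).

The expected step is no change at the digits printed from compound 3 to compound 4 (within the scatter).

For compound 4 the estimated value is 110000 nM, with an expected range of 55000 nM to 220000 nM.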

Compound 4, half-maximal cytotoxic concentration: 82000 nM
Estimate against measurement, compound 4: 1.3-fold (0.13 log units) above; measured number inside the range.
By their numbers in this assay, from the lowest: compounds 4, 1, 3 and 2 (each within the scatter of the next).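

In this assay, going by these compounds alone, 1-acetylpiperidin-4-yl, the first group here with a six-membered non-aromatic ring, stays within the scatter of all three open-chain groups on this carbonyl carbon (a 1.3-fold lower number from compound 3 to compound 4 (0.13 log units; within the scatter)) (a 1.6-fold lower number from compound 2 to compound 4 (0.20 log units; within the scatter)) (a 1.2-fold lower number from compound 1 to compound 4 (0.06 log units; within the scatter)). Neither the added ring nor the missing hydrogen-bond donor of compound 4 relative to compound 3 gives a step beyond the scatter. No measurement at hand bears on the reason for this result.

Open, from the compounds shown here alone, is whether a free amine or a carboxylic acid on this carbonyl carbon would separate from these four compounds. Equally open, going by these compounds, is whether changes on the shared core would.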